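A few compounds are considered here, and "the series" means these few. Any claim that something is new, unique, unknown or untested is made for them only; others in the source may bear on it.

The measured compounds:
compound 1 `Cn1cc2c(Cl)nc(N)nc2n1`: > 20000 nM
compound 2 `CC(C)n1cc2c(Cl)nc(NC(=O)c3ccc(C(F)(F)F)cc3)nc2n1`: > 20000 nM
compound 3 `Cc1ccc(C(=O)Nc2nc(Cl)c3cn(C(C)C)nc3n2)cc1`: > 20000 nM

In a functional assay on CHO cells for antagonist activity at adenosine receptor A2b (Homo sapiens), read by 33P incorporation, with a stated time of 20 min, in the presence of a further agent that is not named here (on this read-out lower numbers stand for stronger inhibition and higher numbers for weaker inhibition), compound 1 gives > 20000 nM, which is a limit of the assay and not a number. Compound 2 gives > 20000 nM, again a limit. Compound 3 gives > 20000 nM, also a limit. Going by the values given here, the one step between measured compounds, a step that the two limits leave unreadable from compound 2 to compound 3, cannot be read, because both of its ends sit at the limit of > 20000 nM in this assay, at which 3 of the 3 values shown sit. Compound 1 therefore stands nowhere in particular on the numbers shown: every value is a limit.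

Compound 4 `CC(C)(C)Cn1cc2c(Cl)nc(N)nc2n1` differs from compound 1 by tert-butyl in place of hydrogen on a saturated chain carbon bound to an aromatic nitrogen. Among the compounds with values here, no measured step bears on this change, and no measured compound yields a number at all, so there is nothing on which a size or direction of step could rest. The expectation for compound 4 in this assay is therefore that it stays at the limit, which means an expected step of a number no higher from compound 1 to compound 4 (the limit leaves the size open). The estimate for compound 4 is 20000 nM, ranging from 5000 nM to 80000 nM.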

Compound 4, inhibition constant: > 10000 nM
Compound 4: a limit, no number (the forecaster's own chance of this, stated with the estimate: 75%); the middle value is on the limit's open side.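

In this assay compound 4 gives > 10000 nM, which is a limit and not a number. With limits at both ends, no step can be read between compound 1 and compound 4. The compounds shown leave open whether tert-butyl in place of hydrogen changes inhibition at all, since none of them yields a number.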